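A few compounds are considered here, and "the series" means these few. Any claim that something is new, unique, unknown or untested is made for them only; others in the source may bear on it.

Measured compounds:
compound 1 `CC1=C(C(=O)Nc2ccccc2)C(c2cn(-c3ccccc3)nc2-c2ccccc2)NC(=S)N1` — 88200 nM
compound 2 `CC1=C(C(=O)Nc2ccc(C)cc2)C(c2cn(-c3ccccc3)nc2-c2ccccc2)NC(=S)N1` — 56100 nM
compound 3 `COc1ccc(NC(=O)C2=C(C)NC(=S)NC2c2cn(-c3ccccc3)nc2-c2ccccc2)cc1` — 77300 nM

In a functional assay on MCF7 cells (Homo sapiens) for inhibition, read by sulforhodamine B assay, with a stated time of 24 h (on this read-out lower numbers stand for stronger inhibition of growth and higher numbers for weaker inhibition of growth), compound 3 holds the second highest of the three numbers; its steps to the others, a 1.1-fold lower number from compound 1 to compound 3 (0.06 log units; within the scatter) and a 1.4-fold higher number from compound 2 to compound 3 (0.14 log units; within the scatter), both lie within the scatter. Compound 4 `CC1=C(C(=O)Nc2ccc([N+](=O)[O-])cc2)C(c2cn(-c3ccccc3)nc2-c2ccccc2)NC(=S)N1` differs from compound 3 by nitro in place of methoxy on an aromatic carbon. Among the measured compounds shown here, the steps that bear on this change are the three substitutions at the same aromatic carbon, a 1.6-fold lower number from compound 1 to compound 2 (0.20 log units; within the scatter), a 1.1-fold lower number from compound 1 to compound 3 (0.06 log units; within the scatter) and a 1.4-fold higher number from compound 2 to compound 3 (0.14 log units; within the scatter), none of them beyond the scatter. For the measured compounds named here, no measured compound carries a nitro group, so nothing points to a step in either direction. Compound 4 is therefore expected at 75000 nM, with a range from 30000 nM to 180000 nM. The expected step, a 1.0-fold lower number from compound 3 to compound 4 (0.01 log units; within the scatter), is within the scatter.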

Compound 4, concentration for 50% growth inhibition: 41400 nM
For compound 4 the middle estimate is 1.8-fold (0.26 log units) above the measured one; the measured number falls inside the stated range.
By their numbers in this assay, from the lowest: compounds 4, 2, 3 and 1 (each within the scatter of the next, the first and the last beyond it).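

In this assay, a change at this aromatic carbon, para to a large group, now gives its first step beyond the scatter: nitro in place of hydrogen gives a 2.1-fold lower number from compound 1 to compound 4 (0.33 log units; beyond the scatter) and this step is modest. Nitro is not separated from the other two groups, since a 1.9-fold lower number from compound 3 to compound 4 (0.27 log units; within the scatter) and a 1.4-fold lower number from compound 2 to compound 4 (0.13 log units; within the scatter) both stay within the scatter. Thus only the comparison with hydrogen stands out. No evidence is available to explain this step. The compounds shown leave open whether an amine or a carboxylic acid at this carbon would give a larger step.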